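A few compounds are considered here, and "the series" means these few. Any claim that something is new, unique, unknown or untested is made for them only; others in the source may bear on it.

Working notes on the series, read in an ADME assay on NHDF cells (Homo sapiens) for antiproliferative activity, with a stated time of 72 h; a higher number here means a weaker inhibitor, a lower number a stronger inhibitor:

- compound 1 `CC(=O)Oc1ccccc1/C=C/c1nc2ccccc2c(=O)[nH]1`: > 25000 nM (a limit)
- compound 2 `CC(=O)Oc1ccccc1/C=C/c1nc(Nc2ccccc2I)c2ccccc2n1`: 23200 nM
- compound 3 `COc1ccccc1/C=C/c1nc2ccccc2c(=O)[nH]1`: > 25000 nM (a limit)

Compound 3 gives no number in this assay. It sits at the same limit as compound 1, as the limit of > 25000 nM in this assay, at which 2 of the 3 values shown sit, records. For the measured compounds named here, compound 2 is the only one with a number (23200 nM) and has no measured step to compound 3.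

The next compound is compound 4 `CCOc1ccccc1/C=C/c1nc2ccccc2c(=O)[nH]1`, the ethoxy counterpart of compound 3. The change is methyl in place of hydrogen on a saturated chain carbon bound to an oxygen on an aromatic ring, which is methyl in place of hydrogen on a saturated chain carbon bound to an oxygen on an aromatic ring, or methoxy to ethoxy.

Going by the values given here, only one measured step touches this oxygen, and it is a step that the two limits leave unreadable from compound 1 to compound 3. Among the compounds with values here, it therefore gives no size to carry over, and no step of the present kind has been measured. The expectation rests on compound 3 with its limit of > 25000 nM and on compound 1 with its limit of > 25000 nM. No step beyond the scatter is expected, and no direction can be assigned.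

The expected step is a step that the limit leaves unreadable from compound 3 to compound 4. Another limit is the likeliest report. For compound 4 the estimated value is 28000 nM, with an expected range of 16000 nM to 50000 nM.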

Compound 4, half-maximal inhibitory concentration: > 25000 nM
Compound 4: only a limit was reported; the forecaster's own chance of this, stated with the estimate: 80%; the middle value does not contradict the limit.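

Compound 4 also gives only a limit, so the steps linking compound 4 to compound 3 and to compound 1 cannot be read: the limit of > 25000 nM in this assay, at which 3 of the 4 values shown sit.

The compounds shown leave open whether methoxy to ethoxy, or any other change on this oxygen, alters the read-out in this assay at all.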